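This account rests on a few compounds, and the source may have more. Where it says the series, first, only, none or still open, it means among the compounds named here.

Measured so far in an ADME assay on a cell-free system (plasma, Homo sapiens) for metabolic stability, read by HPLC (a lower number here means that the compound disappears faster, a higher number that the compound lasts longer), are two compounds:
- compound 1 `CN(/N=N/c1ccc(C#N)cc1)C(=O)CCCCc1ccc(O)cc1` with 11.8 h
- compound 2 `Cc1ccc(/N=N/N(C)C(=O)CCCCc2ccc(O)cc2)cc1` with 79.7 h

Among the compounds with values here, of the two, compound 2 holds the higher number in this assay and is the longest-lasting compound measured so far. Compound 3 `COC(=O)c1ccc(/N=N/N(C)C(=O)CCCCc2ccc(O)cc2)cc1` is still unmeasured. The change is methoxycarbonyl in place of methyl on an aromatic carbon and amounts to methoxycarbonyl in place of methyl on an aromatic carbon, para to a large group.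

Within the data shown here, only one measured step bears on this place. It is a 6.8-fold higher number from compound 1 to compound 2 (0.83 log units; beyond the scatter) and came with methyl in place of cyano, a modest step beyond the scatter. Read in reverse, it shows that the one compound without methyl there has the lower number. Among the measured compounds shown here, no measured compound carries methoxycarbonyl, so this single pair is a thin guide.

With compound 1 at 11.8 h as the only lower reference, a downward step of similar or somewhat smaller size is expected, beyond the scatter. The expected change is a 4.4-fold lower number from compound 2 to compound 3 (0.65 log units; beyond the scatter) by this estimate. Compound 3 is therefore estimated at 18 h with 6 h to 50 h as the likely range.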

Compound 3, half-life: 17.5 h
Compound 3: middle estimate off by 1.0-fold (0.01 log units), on the high side, within the range that was stated.
By their numbers in this assay, from the lowest: compounds 1 and 3 (each within the scatter of the next); then compound 2.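

In this assay, the change to methoxycarbonyl on the aromatic carbon, para to a large group, gives a 4.6-fold lower number from compound 2 to compound 3 (0.66 log units; beyond the scatter) and so adds a second group to set against methyl at this position, where the earlier pair offered only cyano. Methoxycarbonyl and cyano do not separate from each other, with a 1.5-fold higher number from compound 1 to compound 3 (0.17 log units; within the scatter) as the step between them, even though they are different groups. Across these three compounds the position therefore shows two levels, with compound 2 standing apart and compounds 1 and 3 together, a grouping that rests on methyl alone on one side and on only two groups on the other.

No evidence is at hand on what lies behind this split in how long the compounds last. The compounds shown also leave open whether an ethyl group, an amine or a carboxylic acid at this same position would fall with methyl or with cyano and methoxycarbonyl, and whether the split would hold on a different chain in the rest of the shared core.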